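The source may report more compounds than this note shows. Statements on the series, on what has been measured and on what is new or still open speak of the compounds shown alone.

Measured compounds:
compound 1 `Cc1ccc(-c2cn(-c3ccc(CN4CCN(C)CC4)cc3)nn2)cc1Nc1nccc(-c2cccnc2)n1` — 6160 nM
compound 2 `CCN(CC)c1ccc(-n2cc(-c3ccc(C)c(Nc4nccc(-c5cccnc5)n4)c3)nn2)cc1` — 2930 nM
compound 3 `Cc1ccc(-n2cc(-c3ccc(CN4CCN(C)CC4)c(C(F)(F)F)c3)nn2)cc1Nc1nccc(-c2cccnc2)n1` — 1270 nM

In a functional assay on KG-1a cells (Homo sapiens) for inhibition, read by MTT assay, with a stated time of 72 h (on this read-out higher numbers stand for weaker inhibition and lower numbers for stronger inhibition), compound 3 stands at the lowest of the three numbers; compound 2 is nearest and compound 1 furthest, and both of those gaps lie beyond the scatter. Compound 4 `Cc1ccc(-n2cc(-c3ccc(C)c(C(F)(F)F)c3)nn2)cc1Nc1nccc(-c2cccnc2)n1` differs from compound 3 by hydrogen in place of 4-methylpiperazin-1-yl on a saturated chain carbon bound to an aromatic carbon. Going by the values given here, the only measured step that bears on a change of this kind is a 2.1-fold lower number from compound 1 to compound 2 (0.32 log units; beyond the scatter), but that exchange sits on a different aromatic ring and brings in diethylamino rather than hydrogen. Among the compounds with values here, no measured step removes this group without replacement, so the evidence is thin, and a step within the scatter in either direction seems most likely. Compound 4 is therefore expected to give 1500 nM (range 500 nM to 5000 nM), an estimated step of a 1.2-fold higher number from compound 3 to compound 4 (0.07 log units; within the scatter).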

Compound 4, half-maximal inhibitory concentration: > 30000 nM
Compound 4 ended at the assay's limit; the forecaster's own chance of this, stated with the estimate: 5%; middle value at least 20-fold (1.30 log units) from the limit.
By their numbers in this assay, from the lowest: compound 3; then compound 2; then compound 1. At a limit, above all of these: compound 4.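

In this assay, going by these compounds alone, hydrogen in place of 4-methylpiperazin-1-yl on this carbon gives an at least 23-fold higher number from compound 3 to compound 4 (1.37 log units; beyond the scatter), a large step, whereas the only earlier step, a 2.1-fold lower number from compound 1 to compound 2 (0.32 log units; beyond the scatter), was modest and concerned a diethylamino exchange. This shows that the group cannot simply be dropped from this place without a heavy loss of inhibition. The value of compound 4 is a limit and not a number: the limit of > 30000 nM in this assay, at which 1 of the 4 values shown sits.

The compounds shown leave open whether 4-methylpiperazin-1-yl itself is needed here or whether another amine, such as dimethylamino or morpholine, would serve. They also leave open what a hydroxyl on the same carbon would give.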